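The source may report more compounds than this note shows. Statements on the series, on what has been measured and on what is new or still open speak of the compounds shown alone.

Measured so far:
compound 1, `CCN(Cc1nc2cc(C(F)(F)F)ccc2nc1-c1ccccc1)c1ccc(C)cc1`: in an assay on isolated protein for inhibition of Dihydrofolate reductase (Homo sapiens), read by spectrophotometry (a lower number here means a stronger inhibitor, a higher number a weaker inhibitor), compound 1 gives 4000 nM.
compound 2, `CCN(Cc1nc2cc(C(F)(F)F)ccc2nc1-c1ccccc1)c1ccc(OC)cc1`: in this assay compound 2 gives 7000 nM.

Compound 2 stands at the highest of the two numbers shown; its nearest neighbour is compound 1, and the step of a 1.8-fold higher number from compound 1 to compound 2 (0.24 log units; within the scatter) lies within the scatter, so the two compounds cannot be told apart on these data.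

Compound 3, `CCN(Cc1nc2cc(C(F)(F)F)ccc2nc1-c1ccccc1)c1ccc(OC(F)(F)F)cc1`, differs from compound 2 by trifluoromethyl in place of methyl on an oxygen on an aromatic ring. For the measured compounds named here, the only measured step, a 1.8-fold higher number from compound 1 to compound 2 (0.24 log units; within the scatter), concerns methyl to methoxy on an aromatic carbon and was within the scatter; no measured step covers trifluoromethyl in place of methyl on the oxygen. With nothing bearing directly on this change, the expected step in this assay from compound 2 to compound 3 is no change at the digits printed from compound 2 to compound 3 (within the scatter), that is none beyond the scatter. Compound 3 is accordingly estimated at 7000 nM, with a range from 2500 nM to 20000 nM.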

Compound 3, inhibition constant: 5000 nM
Beside the measured number, compound 3's estimate is 1.4-fold (0.15 log units) above it; measured number inside the range.
By their numbers in this assay, from the lowest: compounds 1, 3 and 2 (each within the scatter of the next).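

For the compounds shown here, replacing the methyl of the methoxy group with trifluoromethyl, a change of one heavy atom for four, gives no step that can be told from scatter in this assay (a 1.4-fold lower number from compound 2 to compound 3 (0.15 log units; within the scatter)). The comparison with the methyl-bearing compound gives the same reading (a 1.3-fold higher number from compound 1 to compound 3 (0.10 log units; within the scatter)), so methyl, methoxy and trifluoromethoxy at this place on the aromatic ring cannot be separated, and with all three compounds within the scatter of one another, no order among them can be drawn. No measurement on hand bears on these results.

Open, as far as these compounds go, is whether any group at this place moves the number beyond the scatter, for example an amine, a carboxylic acid or a longer alkoxy chain. Also open, from the compounds shown here alone, is whether changes elsewhere on the shared core, such as replacing the ethyl on the nitrogen, do so.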